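A few compounds are considered here, and "the series" means these few. Any claim that something is new, unique, unknown or untested is made for them only; others in the source may bear on it.

Working notes on the series. Compound 3 `CCCCCCCCC(=O)N1c2ccccc2CCC1C(=O)Nc1ccccc1O` gives 65000 nM in a functional assay on ACHN cells (Homo sapiens) for cytotoxicity, read by sulforhodamine B assay, with a stated time of 72 h (on this read-out higher numbers stand for weaker inhibition of growth and lower numbers for stronger inhibition of growth), the highest number among the three measured compounds; the nearest is compound 1 `CCCCCCCCC(=O)N1c2ccccc2CCC1C(=O)Nc1ccccc1C(F)(F)F` at 8330 nM, the furthest compound 2 `O=C(Nc1cc(C(F)(F)F)cc(C(F)(F)F)c1)C1CCc2ccccc2N1C(=O)c1ccc(Cl)cc1` at 2570 nM. Going by the values given here, the one single-point step on record, a 7.8-fold higher number from compound 1 to compound 3 (0.89 log units; beyond the scatter), concerns the aryl side, not the acyl side. Compound 4 `O=C(Nc1ccccc1O)C1CCc2ccccc2N1C(=O)c1ccc(Cl)cc1` carries the change (4-chlorophenyl in place of octyl on a carbonyl carbon). Among the compounds with values here, no measured step isolates this change: compound 2, the only chlorophenyl example, also differs from compound 1 on the aryl side, so the two values show only that the pair differ. Compound 4 is therefore expected near compound 3, tending to a lower number, with a 1.6-fold lower number from compound 3 to compound 4 (0.21 log units; within the scatter) as the estimated step, giving 40000 nM in a range of 10000 nM to 150000 nM.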

Compound 4, concentration for 50% growth inhibition: 19600 nM
Compound 4: middle estimate off by 2.0-fold (0.31 log units), on the high side; measured number inside the range.
By their numbers in this assay, from the lowest: compound 2; then compound 1; then compound 4; then compound 3.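

With the aryl side held fixed, the acyl position now has its first isolated step: 4-chlorophenyl in place of octyl on a carbonyl carbon gives a 3.3-fold lower number from compound 3 to compound 4 (0.52 log units; beyond the scatter) in this assay. The acyl side thus moves the read-out on its own, and in this one pair the aromatic ring gives stronger inhibition of growth than the octyl chain. Nothing on record accounts for the step.

Going by these compounds, compound 1 and compound 2 differ in more than one place, and whether the step holds with trifluoromethyl on the aryl side stays open. Also open, on these data alone, is how a chain longer than octyl or a 4-methoxyphenyl group would read on that carbonyl carbon.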